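Compound 1 and its Nitro Counterpart, Compound 4

The compounds below may be only part of what the source reports. "The series", "measured", "known", "first", "only" and "open" are said of these compounds alone.

Measured in a physicochemical assay for lipophilicity; a higher number here means a more lipophilic compound, a lower number a more polar compound:
- Compound 1 `CCSc1ccccc1C1=NC(c2ccccc2)CO1` gives 4.04
- Compound 2 `Fc1cccc(Cl)c1C1=NC(c2ccccc2)CO1` gives 3.45
- Compound 3 `Clc1ccc(C2=NC(c3ccccc3)CO2)cc1` gives 4.48

Among these three numbers, compound 1 stands second highest. Compound 3 lies above it and compound 2 lies below it, and both gaps are beyond the usual scatter.

The next compound to be measured is compound 4 `O=[N+]([O-])c1ccccc1C1=NC(c2ccccc2)CO1`. It differs from compound 1 in one place, with nitro in place of ethylsulfanyl on an aromatic carbon. The rest of the structure is unchanged.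

Within the data shown here, no measured pair shows this exchange, and the three values do not isolate it, so the expectation rests on the structural change alone. The expected step in this assay is downward and beyond the scatter: a number 0.94 log units lower from compound 1 to compound 4 (beyond the scatter). That would place compound 4 near the low end of the series or under it. The value of compound 4 is estimated at 3.1, within an expected range from 2.6 to 3.6.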

Compound 4, partition coefficient: 2.83
For compound 4 the middle estimate is 0.27 log units above the measured one; low and high end bracket the measured number.
By their numbers in this assay, from the lowest: compound 4; then compound 2; then compound 1; then compound 3.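

In this assay, among these compounds, the exchange of ethylsulfanyl for nitro on this aromatic carbon, ortho to a large group, gives a number 1.21 log units lower from compound 1 to compound 4 (beyond the scatter) and so supplies the first step between compounds that differ in one place. It shows that the reading at this position is sensitive to the identity of the group: the count of 3 heavy atoms stays the same, yet carbon and sulfur giving way to nitrogen and oxygen moves the number well past the scatter. Nothing available accounts for the size of this step.

The compounds shown leave open whether another group on this carbon, such as an amine or a carboxylic acid, would bring a step of similar size. From the compounds shown here alone, it also stays open whether the same exchange would give such a step elsewhere on the aromatic ring, or starting from a longer chain than ethylsulfanyl.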